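Swapping the Nitrobenzyl Arm for Propyl on a Shared Core

A few compounds are considered here, and "the series" means these few. Any claim that something is new, unique, unknown or untested is made for them only; others in the source may bear on it.

Of the compounds shown here, two built on a shared core have been measured for how strongly they hold back cell growth in an ADME assay on GES1 cells (Homo sapiens) for inhibition, read by MTT assay, with a stated time of 72 h; on this read-out lower numbers stand for stronger inhibition and higher numbers for weaker inhibition. Compound 1 `Cc1cc(Nc2cc(-c3ccccc3)[nH]n2)n2nc(SCc3ccc([N+](=O)[O-])cc3)nc2n1` gives 43600 nM, which is the highest number of the two. Compound 2 `Cc1cc(Nc2cc(-c3ccc(Cl)cc3)[nH]n2)n2nc(SCc3ccc(Br)cc3)nc2n1` gives 28200 nM; the two numbers lie close enough that they count as the same within the usual scatter of this kind of measurement. Compound 3 `CCCSc1nc2nc(C)cc(Nc3cc(-c4ccccc4)[nH]n3)n2n1` has not yet been measured in this assay. It differs from compound 1 in a single place: ethyl in place of 4-nitrophenyl on a saturated chain carbon bound to a sulfur. For the measured compounds named here, both measured compounds carry an aromatic ring on the saturated chain carbon bound to a sulfur, whereas compound 3 carries only a short chain there, and no measured pair shows what removing such a ring does in this assay. With only weak inhibition seen so far, the change is expected to bring a modest step, most likely toward a higher number, and the expected step of a 1.4-fold higher number from compound 1 to compound 3 (0.14 log units; within the scatter) reflects that. Compound 3 is therefore estimated at 60000 nM, with a range from 25000 nM to 150000 nM.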

Compound 3, half-maximal inhibitory concentration: > 50000 nM
Compound 3: only a limit was reported; the forecaster's own chance of this, stated with the estimate: 25%; the middle value is on the limit's open side.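

In this assay compound 3 gives > 50000 nM, which is a limit and not a number. For the compounds shown here, this is the first pair of compounds that differ only in the group on a saturated chain carbon bound to a sulfur, and going from 4-nitrobenzyl to propyl gives an at least 1.1-fold higher number from compound 1 to compound 3 (0.05 log units; that floor lies within the scatter), so this change, which removes the aromatic ring, brings no stronger inhibition. That step is only a floor, and its true size cannot be read because the measurement of compound 3 ends at a limit: the limit of > 50000 nM in this assay, at which 1 of the 3 values shown sits.

The compounds shown leave open whether a longer chain such as hexyl, or a propyl chain ending in an amine or a carboxylic acid, would give a number that can be read at this place. Also open, going by these compounds, is what plain benzyl would give, since that group keeps the aromatic ring without the nitro group and could show which of the two parts of 4-nitrobenzyl matters for the read-out.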